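The source may report more compounds than this note shows. Statements on the series, on what has been measured and on what is new or still open speak of the compounds shown alone.

Working notes on the series in an ADME assay on HEK293 cells (Homo sapiens) for cytotoxicity, read by sulforhodamine B assay, with a stated time of 48 h, tested at 10 uM; on this read-out higher numbers stand for more inhibition at the one concentration tested (going by the name of the read-out) and lower numbers for less inhibition.

Three compounds share one core and differ only in the group on the five-membered aromatic ring with three nitrogens. Compound 1 `CCCCCCCc1cn(C(c2ccccc2)c2cc3cc(Br)ccc3nc2OC)nn1` gives 0.17%. Compound 2 `CCCCCCc1cn(C(c2ccccc2)c2cc3cc(Br)ccc3nc2OC)nn1` gives -3.17%. Compound 3 `CCCc1cn(C(c2ccccc2)c2cc3cc(Br)ccc3nc2OC)nn1` gives 0.85%. Compound 3 holds the highest of the three numbers, but the two steps leading to it are a number 0.7 percentage points higher from compound 1 to compound 3 (within the scatter) and a number 4 percentage points higher from compound 2 to compound 3 (within the scatter), so the three stand level within the scatter. The remaining pair shows a number 3.3 percentage points lower from compound 1 to compound 2 (within the scatter).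

Compound 4 `COc1nc2ccc(Br)cc2cc1C(c1ccccc1)n1cc(-c2ccc(F)cc2)nn1` has not yet been measured in this assay. It differs from compound 3 by 4-fluorophenyl in place of propyl on an aromatic carbon. Within the data shown here, all measured steps concern shortening or lengthening of a saturated chain at this same carbon, and every one lies within the scatter; none swaps a chain for an aromatic ring, so no measured step bears directly on the change to compound 4. What the series does show is that altering the group on this carbon left this assay unchanged across propyl, hexyl and heptyl.

On that basis the step expected from compound 3 to compound 4 is a number 1.2 percentage points higher from compound 3 to compound 4 (within the scatter), none beyond the scatter. Compound 4 is therefore estimated at 2%, in the range -8% to 14%.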

Compound 4, a percentage reported as inhibition, at one concentration (the size of the read-out at that concentration, not a potency): 4.04%
Beside the measured number, compound 4's estimate is 2 percentage points below it; the measured number falls inside the stated range.
By their numbers in this assay, from the lowest: compounds 2, 1, 3 and 4 (each within the scatter of the next).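

In this assay, the group on the aromatic carbon of the five-membered aromatic ring with 3 nitrogen now changes in kind, from a saturated chain to 4-fluorophenyl with its six-membered aromatic ring of carbon only, and every resulting step stays within the scatter (a number 3.2 percentage points higher from compound 3 to compound 4 (within the scatter); a number 7.2 percentage points higher from compound 2 to compound 4 (within the scatter); a number 3.9 percentage points higher from compound 1 to compound 4 (within the scatter)). The level reading earlier seen only among propyl, hexyl and heptyl therefore extends to one aromatic group at this carbon, and no listed pair among the four compounds separates beyond the scatter. No supporting evidence accompanies these readings to account for this flat picture.

The compounds shown leave open whether a carboxylic acid, a primary amine or a hydroxymethyl group on this same carbon would also stay level with the chains and the 4-fluorophenyl group. They also leave open whether replacing the bromine or the methoxy group on the shared core, rather than changing this group, would produce a step beyond the scatter in this read-out.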